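This account rests on a few compounds, and the source may have more. Where it says the series, first, only, none or still open, it means among the compounds named here.

Working notes on the series. The shared core appears in compound 1 `COc1cc(NC(C)CCCNC(=O)Nc2ccc(C(F)(F)F)cc2)c2ncccc2c1` and compound 2 `COc1cc(NC(C)CCCNC(=O)NNC(=O)Nc2cccc(Cl)c2)c2ncccc2c1`. In a functional assay on MIA PaCa-2 cells (Homo sapiens) for inhibition, read by MTT assay, with a stated time of 72 h (on this read-out lower numbers stand for stronger inhibition and higher numbers for weaker inhibition), compound 1 gives 8400 nM, and compound 2 gives 74000 nM. Among the compounds with values here, compound 2 stands at the highest of the two numbers measured so far, its nearest neighbour being compound 1; the only measured step is an 8.8-fold higher number from compound 1 to compound 2 (0.94 log units; beyond the scatter).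

Compound 3 `COc1cc(NC(C)CCCNC(=O)NNC(=O)Nc2ccc(F)cc2)c2ncccc2c1` has not yet been measured. It differs from compound 2 by 4-fluorophenyl in place of 3-chlorophenyl on an amide-type nitrogen. Within the data shown here, no measured step bears directly on this change: the one step known, an 8.8-fold higher number from compound 1 to compound 2 (0.94 log units; beyond the scatter), puts ((3-chlorophenyl)carbamoyl)amino in place of 4-(trifluoromethyl)phenyl and so alters more than the aryl group alone, leaving no separate reading of an aryl swap. With a single reference point, the expectation in this assay is a step of no clear direction, most likely within the scatter, with a wide range to reflect the thin basis.

Compound 3 is therefore expected to give about 70000 nM, within 25000 nM to 200000 nM. The expected step is a 1.1-fold lower number from compound 2 to compound 3 (0.02 log units; within the scatter).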

Compound 3, half-maximal inhibitory concentration: >= 250000 nM
Compound 3 ended at the assay's limit (the forecaster's own chance of this, stated with the estimate: 20%); middle value at least 3.5-fold (0.55 log units) away from the limit.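

In this assay compound 3 reads as a limit of the assay, not as a number: the limit of >= 250000 nM in this assay, at which 1 of the 3 values shown sits. Even so, the aryl group on the amide-type nitrogen whose other neighbour is the carbonyl carbon is not indifferent here: 4-fluorophenyl in place of 3-chlorophenyl gives an at least 3.3-fold higher number from compound 2 to compound 3 (0.52 log units; beyond the scatter), the first reading of a change confined to that aryl group. The wider comparison gives an at least 29-fold higher number from compound 1 to compound 3 (1.47 log units; beyond the scatter), and with ((4-fluorophenyl)carbamoyl)amino in place of 4-(trifluoromethyl)phenyl it still changes both the aryl group and the stretch that carries it, so it does not separate the two.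

The compounds shown leave open whether the halogen or its place on the ring carries the step from 3-chlorophenyl to 4-fluorophenyl, as both change together; a 4-chlorophenyl or a 3-fluorophenyl group at the same place would part the two. Also open, as far as these compounds go, is how 4-(trifluoromethyl)phenyl behaves on the ((aryl)carbamoyl)amino stretch, which would give a clean reading of that stretch against compound 1.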